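Replacing the ring amide substituent: aryl to cyclohexyl

The compounds below may be only part of what the source reports. "The series", "measured", "known", "first", "only" and "open" are said of these compounds alone.

Measured compounds:
- compound 1 `O=C1COc2ccc(-c3cccc(NS(=O)(=O)c4ccc(F)cc4)c3)cc2N1C1CC1` gives > 40000 nM in a functional assay on HCT-116 cells (Homo sapiens) for antiproliferative activity, read by MTT assay, with a stated time of 72 h; on this read-out lower numbers stand for stronger inhibition and higher numbers for weaker inhibition; this is a limit of the assay, not a number.
- compound 2 `O=C1COc2ccc(-c3cnc4ccccc4c3)cc2N1` gives > 40000 nM in this assay; again a limit.
- compound 3 `O=C1COc2ccc(-c3cccc(NS(=O)(=O)c4ccc(F)cc4)c3)cc2N1c1ccc(Cl)cc1` gives 23900 nM in this assay.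

Within the data shown here, compound 3 holds the only number in this assay; the other two values are limits (the limit of > 40000 nM in this assay, at which 2 of the 3 values shown sit). Among the measured compounds shown here, the step of an at least 1.6-fold lower number from compound 1 to compound 3 (0.22 log units; that floor lies within the scatter) is the only measured change at the amide-type nitrogen in the ring, and its floor lies within the scatter. Compound 4 `O=C1COc2ccc(-c3cccc(NS(=O)(=O)c4ccc(F)cc4)c3)cc2N1C1CCCCC1` carries cyclohexyl in place of 4-chlorophenyl on an amide-type nitrogen in a ring. No measured step pairs cyclohexyl with any other group here, so the shown evidence supports no expected change beyond the scatter. Compound 4 is therefore estimated at 30000 nM, from 10000 nM to 90000 nM, meaning an expected step of a 1.3-fold higher number from compound 3 to compound 4 (0.10 log units; within the scatter), with a real chance that only a limit is reported.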

Compound 4, half-maximal inhibitory concentration: 18300 nM
For compound 4 the middle estimate is 1.6-fold (0.21 log units) above the measured one; the range from low to high includes it.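

In this assay, cyclohexyl on the amide-type nitrogen in the ring reads the same as 4-chlorophenyl within the scatter, a 1.3-fold lower number from compound 3 to compound 4 (0.12 log units; within the scatter), so an aromatic ring at this position is not required for a measurable value. Cyclohexyl in place of cyclopropyl gives the first step at this nitrogen that clears the scatter, an at least 2.1-fold lower number from compound 1 to compound 4 (0.33 log units; beyond the scatter). That step starts from compound 1 at > 40000 nM, which is a limit and not a number. As far as these compounds go, whether a longer chain or an amine on this nitrogen would move the value beyond the scatter remains open.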